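This account rests on a few compounds, and the source may have more. Where it says the series, first, only, none or still open, it means among the compounds named here.

Compound 1 `CC(=O)Nc1ccc(S(=O)(=O)Nc2cccc(-c3nc(-c4ccc(NC(=O)c5cccnc5)cc4Cl)no3)c2)cc1` — in a functional assay on MDA-MB-231 cells (Homo sapiens) for antiproliferative activity, read by MTT assay, with a stated time of 72 h (a higher number here means a weaker inhibitor, a lower number a stronger inhibitor), compound 1 gives 2500 nM.
Compound 2 `CC(=O)Nc1ccc(S(=O)(=O)Nc2cccc(-c3nc(-c4ccc(NC(=O)c5cccnc5)cc4)no3)c2)cc1` — in this assay compound 2 gives 5200 nM.

Going by the values given here, compound 2 stands highest of these two numbers; the only step, a 2.1-fold higher number from compound 1 to compound 2 (0.32 log units; beyond the scatter), came with hydrogen in place of chloro on an aromatic carbon. Compound 3 `CC(=O)Nc1ccc(S(=O)(=O)Nc2cccc(-c3nc(-c4ccc(NC(=O)c5cccnc5)cc4C(F)(F)F)no3)c2)cc1` differs from compound 2 by trifluoromethyl in place of hydrogen on an aromatic carbon. Among the compounds with values here, the one measured step that bears on this is a 2.1-fold higher number from compound 1 to compound 2 (0.32 log units; beyond the scatter), where removing the chloro from that aromatic carbon raised the number. Placing a trifluoromethyl on the same aromatic carbon is expected to lower the number by a comparable amount, a 2.1-fold lower number from compound 2 to compound 3 (0.32 log units; beyond the scatter). Compound 3 is therefore estimated at 2500 nM, with a range from 1100 nM to 5500 nM.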

Compound 3, half-maximal inhibitory concentration: > 10000 nM
Compound 3: a limit, no number (the forecaster's own chance of this, stated with the estimate: 3%); middle value at least 4.0-fold (0.60 log units) from the limit.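

In this assay compound 3 gives a limit and not a number: the limit of > 10000 nM in this assay, at which 1 of the 3 values shown sits. Putting trifluoromethyl in place of chloro on this aromatic carbon gives an at least 4.0-fold higher number from compound 1 to compound 3 (0.60 log units; beyond the scatter), so these two groups are not interchangeable here, and a group at this carbon does not always lower the number. Against hydrogen the change gives an at least 1.9-fold higher number from compound 2 to compound 3 (0.28 log units; that floor lies within the scatter), and this floor alone cannot separate trifluoromethyl from hydrogen.

Going by these compounds, the true value of compound 3 stays open. So does what a methyl group or an amine on this carbon would give.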